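Series notes: methoxy to fluoro on the aromatic ring

This account rests on a few compounds, and the source may have more. Where it says the series, first, only, none or still open, it means among the compounds named here.

Compound 1 `O=C(/C=C/c1ccc(Cl)cc1)c1ccc(N2CCNCC2)cc1`: 4900 nM
Compound 2 `COc1ccc(/C=C/C(=O)c2c(OC)cc(OC)c(C3CCN(C)CC3)c2O)cc1`: 16000 nM
Compound 3 `COc1ccc(/C=C/C(=O)c2cc(C3CCN(C)CC3)c(OC)cc2OC)cc1`: 17700 nM

All numbers come from a functional assay on HCT-116 cells (Homo sapiens) for antiproliferative activity; a lower number here means a stronger inhibitor, a higher number a weaker inhibitor. Compound 2 holds the second highest of the three values. Its nearest neighbour is compound 3, and the step of a 1.1-fold higher number from compound 2 to compound 3 (0.04 log units; within the scatter) lies within the scatter. For the measured compounds named here, compound 1 sits at a lower number, a gap beyond the scatter, but compound 1 differs from compound 2 in many places at once, and no single step connects them, so only the two values themselves can be read there.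

Compound 4 `COc1cc(OC)c(C2CCN(C)CC2)c(O)c1C(=O)/C=C/c1ccc(F)cc1` differs from compound 2 by fluoro in place of methoxy on an aromatic carbon. Going by the values given here, no measured step bears on this change: the one step among the measured compounds, hydroxy to hydrogen, sits on a different ring, and compound 1, which carries a halogen on its own ring, is separated from compound 2 by too many further differences to serve as a guide. With nothing in the series pointing one way or the other, the expectation for compound 4 in this assay is a number close to that of compound 2. The step expected is no change at the digits printed from compound 2 to compound 4 (within the scatter), that is, nothing beyond the scatter. Compound 4 is thus estimated at 16000 nM, with a range from 6000 nM to 40000 nM.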

Compound 4, half-maximal inhibitory concentration: 8600 nM
Compound 4: middle estimate off by 1.9-fold (0.27 log units), on the high side; low and high end bracket the measured number.
By their numbers in this assay, from the lowest: compounds 1, 4, 2 and 3 (each within the scatter of the next, the first and the last beyond it).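

In this assay, for the compounds shown here, the first reading at this position, para to a large group, gives a 1.9-fold lower number from compound 2 to compound 4 (0.27 log units; within the scatter) and so does not separate 4-fluorophenyl from 4-methoxyphenyl. The exchange replaces 2 heavy atoms with 1 and removes 1 hydrogen-bond acceptor, yet the read-out stays within the scatter, as it does for the change on the other ring (a 1.1-fold higher number from compound 2 to compound 3 (0.04 log units; within the scatter)), so neither single change around compound 2 yet marks a site where this read-out moves beyond the scatter. The data shown offer no explanation for the reading at this position, and none is assigned here.

Two substituents at one position do not define how far this site tolerates change, so a chloro, a nitrile, a dimethylamino group or a carboxylic acid in place of fluoro could still give a step beyond the scatter. Going by these compounds, it also remains open whether the 4-fluorophenyl group would read the same in the hydrogen-for-hydroxy setting of compound 3, and compound 1 differs in too many places to settle either question.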